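Opening the ring of compound 1

This account rests on a few compounds, and the source may have more. Where it says the series, first, only, none or still open, it means among the compounds named here.

- compound 1 (`O=C(CCCCC1CCSS1)Nc1ccc(Cl)cn1`) with 42.3%
- compound 2 (`O=C(CCCCC1CCSS1)Nc1ccc(Br)cn1`) with "not determined" (no result reported)

Within the data shown here, in a functional assay on PC-3 cells (Homo sapiens) for inhibition, read by MTT assay, with a stated time of 24 h, tested at 100 ug/mL (a lower number here means less inhibition of growth, a higher number more inhibition of growth at the concentration tested), compound 1 gives 42.3% as the only number available. Compound 2 has no reported result, so compound 1 cannot yet be ranked against any other compound. Compound 3 (`O=C(CCCCC(S)CCS)Nc1ccc(Cl)cn1`) keeps the shared core of compound 1 and differs at one place, where the ring gives way to an open chain: a group of 5 heavy atoms (3 carbon, 2 sulfur; no ring) in place of a group of 5 heavy atoms (3 carbon, 2 sulfur; one five-membered non-aromatic ring with 2 hetero atoms), on a saturated chain carbon, four bonds along the chain from a carbonyl carbon. Among the measured compounds shown here, no measured pair shows what such a change does in this assay and the expectation can rest only on compound 1 at 42.3% and on the structural change. The expected shift, a number 2.7 percentage points higher from compound 1 to compound 3 (within the scatter), is no larger than the usual scatter and has no firm direction. Compound 3 is expected at 45% with an estimated range of 25% to 65% in this assay for now.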

Compound 3, percent growth inhibition at one concentration: 32.4%
Estimate against measurement, compound 3: 12.6 percentage points above; measured number inside the range.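

Among these compounds, at the saturated chain carbon, four bonds along the chain from a carbonyl carbon, this pair gives the first reading of ring against open chain: in this assay, 1,3-disulfanylpropyl in place of the five-membered ring with 2 hetero atoms gives a number 9.9 percentage points lower from compound 1 to compound 3 (within the scatter). Opening the ring therefore separates the two compounds by no more than the usual spread of such measurements, and compound 3, at 32.4%, shows that growth inhibition at the concentration tested does not depend on the closed ring. Nothing shown gives a measured reason for this result.

From the compounds shown here alone, what a carboxylic acid, an amine or a longer chain would give at this place remains open. The pair also leaves open whether the open chain and the ring would stay this close in this assay with a group other than chlorine on the shared core.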